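Methoxy in place of chloro: the next step

The source may hold more compounds than are shown below. What is called first, only, known or untested is meant among the compounds shown, and "the series" means these compounds.

Among the compounds with values here, only two compounds have results so far in an ADME assay on Vero cells (Chlorocebus sabaeus) for cytotoxicity; on this read-out higher numbers stand for weaker inhibition and lower numbers for stronger inhibition. Compound 1 (`C[C@@H](c1ccccc1)N1C(=O)c2ccccc2C1=O`) reads > 100000 nM, which is a limit of the assay and not a number. Within the data shown here, compound 2 (`O=C1c2nccnc2C(=O)N1Cc1ccc(Cl)cc1`) gives 88000 nM, the only actual number, so there is no other number to compare it with.

Compound 3 (`COc1ccc(CN2C(=O)c3nccnc3C2=O)cc1`) carries methoxy in place of chloro on an aromatic carbon, para to a large group: methoxy in place of chloro on an aromatic carbon. Among the measured compounds shown here, no measured pair shows what a change of this kind does in this assay. The expectation is therefore no step beyond the usual scatter, with no direction favoured, and it rests on compound 2 reading 88000 nM, where inhibition is already weak. The expected result is a 1.0-fold higher number from compound 2 to compound 3 (0.01 log units; within the scatter). A reading reported only as a limit would not be surprising. For compound 3 the estimate is 90000 nM, with an expected range of 45000 nM to 170000 nM.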

Compound 3, half-maximal inhibitory concentration: > 100000 nM
Compound 3 ended at the assay's limit; the forecaster's own chance of this, stated with the estimate: 45%; middle value at least 1.1-fold (0.04 log units) away from the limit.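

In this assay, methoxy in place of chloro on an aromatic carbon, para to a large group, now has a first reading: an at least 1.1-fold higher number from compound 2 to compound 3 (0.05 log units; that floor lies within the scatter). Compound 3 reads > 100000 nM, which is a limit of the assay and not a number, so the step has a floor but no measured size, and the true difference could lie within the scatter or well beyond it. What the change adds is that methoxy at this position gives no reading on the stronger side of compound 2, and that compound 2 remains the only compound with an actual number, with the rest of the series at the top of the measurable range: the limit of > 100000 nM in this assay, at which 2 of the 3 values shown sit.

Whether any group at this position can move the reading to clearly lower numbers stays open, and the compounds shown give no guide to what an amine, a carboxylic acid or a longer chain would do there. Steps ending at the limit also leave open how far methoxy and chloro truly differ in this assay.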